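Notes on three measured sulfonamides and one pending analogue

The source may report more compounds than this note shows. Statements on the series, on what has been measured and on what is new or still open speak of the compounds shown alone.

In an assay on CHO cells for displacement of a labelled ligand from adenosine receptor A3 (Homo sapiens), read by scintillation counting, with a stated time of 45 min, tested at 1 uM, in the presence of a further agent that is not named here (on this read-out higher numbers stand for more inhibition at the one concentration tested (going by the name of the read-out) and lower numbers for less inhibition), the three measured compounds stand as follows:
compound 1, `CCCn1c(=O)[nH]c2nc(-c3ccc(S(=O)(=O)N4CCN(c5ccc(F)cc5)CC4)cc3)[nH]c2c1=O`: 38%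
compound 2, `CCCn1c(=O)[nH]c2nc(-c3ccc(S(=O)(=O)N4CCN(c5ccc(Br)cc5)CC4)cc3)[nH]c2c1=O`: 29%
compound 3, `CCCn1c(=O)[nH]c2nc(-c3ccc(S(=O)(=O)N4CCN(c5ccccc5C)CC4)cc3)[nH]c2c1=O`: 25%

Compound 1 carries the highest of the three numbers, though only its gap to compound 3 lies beyond the scatter; its gap to compound 2 does not. Compound 4, `CCCn1c(=O)[nH]c2nc(-c3ccc(S(=O)(=O)N4CCN(c5ccccc5Br)CC4)cc3)[nH]c2c1=O`, differs from compound 1 by 2-bromophenyl in place of 4-fluorophenyl on an amine nitrogen in a ring. For the measured compounds named here, two measured steps bear on this change: a number 9 percentage points lower from compound 1 to compound 2 (within the scatter), and a number 13 percentage points lower from compound 1 to compound 3 (beyond the scatter). Both run downward, one within and one beyond the scatter, so a modest fall in this assay is expected for compound 4. The value of compound 4 in this assay is estimated at 24%, with a range of 12% to 36%. The expected step is a number 14 percentage points lower from compound 1 to compound 4 (beyond the scatter).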

Compound 4, a percentage reported as inhibition, at one concentration (the size of the read-out at that concentration, not a potency): 20%
Compound 4: the middle estimate sits 4 percentage points above what was measured; low and high end bracket the measured number.
By their numbers in this assay, from the lowest: compounds 4, 3, 2 and 1 (each within the scatter of the next, the first and the last beyond it).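

In this assay, 2-bromophenyl in place of 4-fluorophenyl gives a number 18 percentage points lower from compound 1 to compound 4 (beyond the scatter) and marks a real loss for a change at this amine nitrogen. Bromo in place of methyl gives a number 5 percentage points lower from compound 3 to compound 4 (within the scatter) and 2-bromophenyl in place of 4-bromophenyl gives a number 9 percentage points lower from compound 2 to compound 4 (within the scatter) so neither change separates compound 4 from its nearest analogues. No evidence on the cause of these steps is available.

From the compounds shown here alone, whether a 2-methoxyphenyl or a pyridyl group at this nitrogen would keep the number of compound 1 stays open. So does the outcome for an unsubstituted phenyl.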